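Cytotoxicity Outlook for a Trifluoroacetamide Analogue

The compounds below may be only part of what the source reports. "The series", "measured", "known", "first", "only" and "open" are said of these compounds alone.

Compound 1 `Nc1cc2c(-n3nc(-c4ccccn4)nc3N)ncnc2cc1Cl` gives 27000 nM in an ADME assay on BJ cells (Homo sapiens) for cytotoxicity, with a stated time of 72 h; on this read-out higher numbers stand for an effect only at larger amounts of compound and lower numbers for an effect already at smaller amounts. For compound 2 `COc1cc2nc(Cl)nc(-n3nc(-c4ccccn4)nc3N)c2cc1OC` this assay reports only a limit, > 13000 nM. For compound 3 `COc1cc2ncnc(-n3nc(-c4ccccn4)nc3N)c2cc1OCCCN(C)C` this assay likewise reports only a limit, > 25000 nM. Compound 3 therefore stands at the upper edge of what was observed, where one other value also sits (the limit of > 25000 nM in this assay, at which 1 of the 3 values shown sits). Compound 4 `COc1cc2ncnc(-n3nc(-c4ccccn4)nc3N)c2cc1OCCCNC(=O)C(F)(F)F` differs from compound 3 in one place (((trifluoromethyl)carbonyl)amino in place of dimethylamino on a saturated chain carbon, three bonds along the chain from an oxygen on an aromatic ring). Among the measured compounds shown here, no measured pair differs in this way, so no step can guide the expectation directly. The expected step in this assay is small, within the scatter: a number no higher from compound 3 to compound 4 (the limit leaves the size open). Compound 4 is thus estimated to give about 25000 nM, with a range from 10000 nM to 60000 nM, and quite possibly only a limit again.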

Compound 4, half-maximal effective concentration: > 7000 nM
Compound 4: only a limit was reported; the forecaster's own chance of this, stated with the estimate: 60%; the middle value is on the limit's open side.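

Among the compounds shown here, compound 3 and compound 4 each carry only a limit, so no step between them can be read. The compounds shown leave open whether ((trifluoromethyl)carbonyl)amino in place of dimethylamino shifts cytotoxicity at all.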